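Urea series on the serine/threonine kinase: notes toward compound 4

The source may hold more compounds than are shown below. What is called first, only, known or untested is meant among the compounds shown, and "the series" means these compounds.

Measured compounds:
compound 1 `CC(C)(C)c1cc(NC(=O)Nc2ccc(F)cc2)n(-c2ccccc2)n1` with 6.5 degrees C in an assay on isolated protein for inhibition of serine/threonine-protein kinase 10 (Homo sapiens), read by thermal shift assay, tested at 10 uM; a higher number here means that the compound stabilises the target more against heat, a lower number that the compound stabilises the target less
compound 2 `CC(C)(C)c1cc(NC(=O)Nc2cc(C(F)(F)F)cc(C(F)(F)F)c2)n(-c2ccccc2)n1` with -0.5 degrees C
compound 3 `Cc1ccc(F)cc1NC(=O)Nc1cc(C(C)(C)C)nn1-c1ccccc1` with 4.1 degrees C

Compound 3 stands second highest of the three numbers. Its nearest neighbour is compound 1, whose value lies higher by the step of a number 2.4 degrees C lower from compound 1 to compound 3 (beyond the scatter), a difference beyond the scatter; compound 2 lies furthest away, and the two values of compound 3 and compound 2 show the lower number for compound 2.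

Compound 4 is `Cc1ccc(NC(=O)Nc2cc(C(C)(C)C)nn2-c2ccccc2)cc1`. The change from compound 3 is 4-methylphenyl in place of 5-fluoro-2-methylphenyl on an amide-type nitrogen. Among the compounds with values here, only one measured step touches the same position: the exchange of the aryl group on the amide-type nitrogen, which moved the value by a number 2.4 degrees C lower from compound 1 to compound 3 (beyond the scatter). That step shows the read-out responds to the aryl group on this nitrogen with a modest swing. Compound 4 carries a single small substituent on that ring, as compound 1 does, rather than the two substituents of compound 3, so a step upward toward the level of compound 1 is expected, of modest size.

The step from compound 3 to compound 4 is expected to be a number 1.9 degrees C higher from compound 3 to compound 4 (beyond the scatter). For compound 4 the expected value in this assay is 6 degrees C, within a range from 3.5 degrees C to 8 degrees C.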

Compound 4, shift of the target's melting temperature: 4.7 degrees C
For compound 4 the middle estimate is 1.3 degrees C above the measured one, within the range that was stated.
By their numbers in this assay, from the lowest: compound 2; then compounds 3 and 4 (each within the scatter of the next); then compound 1.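

In this assay the exchange of 5-fluoro-2-methylphenyl for 4-methylphenyl on the amide-type nitrogen gives a number 0.60 degrees C higher from compound 3 to compound 4 (within the scatter) and so does not separate these two aryl groups, which shows that the read-out does not respond to every change at this position and that a single substituent on the ring does not in itself restore the level of compound 1. The exchange of methyl for fluoro on an aromatic carbon gives a number 1.8 degrees C lower from compound 1 to compound 4 (beyond the scatter) and thus isolates a difference beyond the scatter in one substituent, with no second group on the ring involved, which the earlier step, with its two changes on the ring, could not do. Nothing at hand explains why the fluoro and methyl rings differ in this read-out.

Still open, going by these compounds, is whether the higher number of compound 1 is particular to the fluoro group or is shared by other groups in its place, such as chloro, methoxy or an amine. On these data alone, the other groups on the shared core stay the same throughout, so it is also open whether the difference between the fluoro and methyl rings holds with a cyclopropyl group in place of the tert-butyl group.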